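This account rests on a few compounds, and the source may have more. Where it says the series, first, only, none or still open, it means among the compounds named here.

Of the compounds shown here, three sharing one core have been measured in an assay for inhibition of RAC-alpha serine/threonine-protein kinase (Homo sapiens), read by HTRF, with a stated time of 1 h; on this read-out lower numbers stand for stronger inhibition and higher numbers for weaker inhibition. Compound 1 `Cn1ncc(Cl)c1-c1cc(C(=O)N[C@@H]2CN[C@H](CC(=O)NC3CC3)C[C@H]2c2ccc(Cl)c(Cl)c2)oc1Cl` carries a cyclopropylcarbamoyl group on a saturated chain carbon bound to a saturated ring carbon, and in this assay compound 1 gives 3.95 nM. Compound 2 `Cn1ncc(Cl)c1-c1cc(C(=O)N[C@@H]2CN[C@H](CCN3CCC(O)CC3)C[C@H]2c2ccc(Cl)c(Cl)c2)oc1Cl` gives 5.99 nM in this assay, a step of a 1.5-fold higher number from compound 1 to compound 2 (0.18 log units; within the scatter). Compound 3 `C=CC[C@@H]1C[C@@H](c2ccc(Cl)c(Cl)c2)[C@H](NC(=O)c2cc(-c3c(Cl)cnn3C)c(Cl)o2)CN1` gives 12.4 nM in this assay, the highest of the three numbers: the steps run a 3.1-fold higher number from compound 1 to compound 3 (0.50 log units; beyond the scatter) and a 2.1-fold higher number from compound 2 to compound 3 (0.32 log units; beyond the scatter).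

Compound 4 `COCC[C@@H]1C[C@@H](c2ccc(Cl)c(Cl)c2)[C@H](NC(=O)c2cc(-c3c(Cl)cnn3C)c(Cl)o2)CN1` differs from compound 3 in one place: methoxymethyl in place of vinyl on a saturated chain carbon bound to a saturated ring carbon. The two steps that bear on this change, a 3.1-fold higher number from compound 1 to compound 3 (0.50 log units; beyond the scatter) and a 2.1-fold higher number from compound 2 to compound 3 (0.32 log units; beyond the scatter), both show that a group carrying a hydrogen-bond acceptor in this position gave a lower number than vinyl did. Methoxymethyl brings one acceptor, so a modest move in the same direction is expected, a 1.6-fold lower number from compound 3 to compound 4 (0.19 log units; within the scatter), though a result within the scatter would not surprise. Compound 4 is therefore estimated at 8 nM in this assay, with a range from 3.5 nM to 18 nM.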

Compound 4, half-maximal inhibitory concentration: 7.01 nM
For compound 4 the middle estimate is 1.1-fold (0.06 log units) above the measured one; the measured number falls inside the stated range.
By their numbers in this assay, from the lowest: compounds 1, 2, 4 and 3 (each within the scatter of the next, the first and the last beyond it).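

In this assay methoxymethyl cannot be told apart from vinyl on this saturated chain carbon, as a 1.8-fold lower number from compound 3 to compound 4 (0.25 log units; within the scatter) is a step that lies within the scatter. Compound 4 also cannot be told apart from the cyclopropylcarbamoyl and 4-hydroxypiperidin-1-yl compounds, with a 1.8-fold higher number from compound 1 to compound 4 (0.25 log units; within the scatter) and a 1.2-fold higher number from compound 2 to compound 4 (0.07 log units; within the scatter) both lying within the scatter. So methoxymethyl, with one hydrogen-bond acceptor and no ring, does not settle whether the acceptor matters here, even though compound 1 and compound 2 each stand beyond the scatter from the vinyl compound 3.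

Still open, going by these compounds, is whether a primary amine, a carboxylic acid or a longer chain ending in methoxy in this place would stand clearly apart from compound 4. Nothing available here accounts for these numbers.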